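Swapping the Side Group on a Shared Carbamate Core

The source may report more compounds than this note shows. Statements on the series, on what has been measured and on what is new or still open speak of the compounds shown alone.

Measured so far:
- compound 1, `CCN1CCN(C[C@H]2CN(c3ccc(-n4cc(-c5ccccn5)cn4)c(F)c3)C(=O)O2)CC1`: 2.19
- compound 2, `O=C1CNC(=O)N1C[C@H]1CN(c2ccc(-n3cc(-c4ccccn4)cn3)c(F)c2)C(=O)O1`: 1.25
- compound 3, `O=C1O[C@@H](Cn2ccnc2)CN1c1ccc(-n2cc(-c3ccccn3)cn2)c(F)c1`: 1.73

All three compounds share one core and differ only in the group hanging from the saturated chain carbon bound to a saturated ring carbon. In a physicochemical assay for lipophilicity, read by HPLC, measured as octanol-water partition (a lower number here means a more polar compound, a higher number a more lipophilic compound), compound 1 gives the highest of the three numbers; compound 3 sits nearest to it and compound 2 furthest away, both steps lying beyond the scatter.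

The unmeasured compound 4, `O=C1O[C@@H](Cn2ccnn2)CN1c1ccc(-n2cc(-c3ccccn3)cn2)c(F)c1`, is reached from compound 1 by the change 1H-1,2,3-triazol-1-yl in place of 4-ethylpiperazin-1-yl on a saturated chain carbon bound to a saturated ring carbon

Within the data shown here, two measured steps bear on this. Replacing the same group by a five-membered aromatic ring gave a number 0.46 log units lower from compound 1 to compound 3 (beyond the scatter), and replacing it by a saturated ring carrying two carbonyls gave a number 0.94 log units lower from compound 1 to compound 2 (beyond the scatter). Compound 4 also carries a five-membered aromatic ring at this position, so the nearest guide is compound 3, which gives 1.73 in this assay. A downward step from compound 1 is therefore expected for compound 4, of a size similar to or somewhat larger than the step to compound 3: the expected step is a number 0.64 log units lower from compound 1 to compound 4 (beyond the scatter).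

Compound 4 is estimated at 1.55 in this assay, with a likely range from 1.15 to 1.95.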

Compound 4, partition coefficient: 2
Beside the measured number, compound 4's estimate is 0.45 log units below it; the whole stated range lies below it.
By their numbers in this assay, from the lowest: compound 2; then compounds 3, 4 and 1 (each within the scatter of the next, the first and the last beyond it).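

In this assay the step to the 1H-1,2,3-triazol-1-yl group is a number 0.19 log units lower from compound 1 to compound 4 (within the scatter) and the step between the two five-membered aromatic rings is a number 0.27 log units higher from compound 3 to compound 4 (within the scatter), so compound 4 cannot be told apart from either compound, even though compound 1 and compound 3 are separated by a number 0.46 log units lower from compound 1 to compound 3 (beyond the scatter). Among these compounds, this is the first change at this saturated chain carbon that replaces 4-ethylpiperazin-1-yl without a step beyond the scatter, which shows that losing that group does not by itself bring a clear change in this number. Compound 2 remains clearly separate, with a number 0.75 log units higher from compound 2 to compound 4 (beyond the scatter), and so far only its 2,5-dioxoimidazolidin-1-yl group stands apart from the aromatic rings by more than the scatter.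

No measurement shown here explains why the groups fall this way. On these data alone, it remains open whether a carboxylic acid, a primary amine or a 1H-tetrazol-1-yl group on the same saturated chain carbon would stay close to compound 4 or move towards compound 2.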